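The Halogenated Phenyl Ring Gives Way to a Thiophene

A few compounds are considered here, and "the series" means these few. Any claim that something is new, unique, unknown or untested is made for them only; others in the source may bear on it.

Measured compounds:
compound 1 `O=C(Nc1ccc(Cl)cc1)Nc1ccc(Oc2ccc(-c3nccs3)cc2)cc1` — 32.5%
compound 2 `O=C(Nc1ccc(Oc2ccc(-c3nccs3)cc2)cc1)Nc1ccc(F)c(Cl)c1` — 43.9%

In a functional assay on MDA-MB-231 cells (Homo sapiens) for inhibition, read by MTT assay and WST assay, with a stated time of 72 h, tested at 10 uM (on this read-out lower numbers stand for less inhibition of growth and higher numbers for more inhibition of growth at the one concentration tested), compound 1 gives 32.5% and compound 2 gives 43.9%. Compound 2 stands highest of the two values, separated from compound 1 by the step of a number 11.4 percentage points higher from compound 1 to compound 2 (beyond the scatter). Compound 3 `CC(=O)Oc1sccc1NC(=O)Nc1ccc(Oc2ccc(-c3nccs3)cc2)cc1` carries the change (2-acetoxythiophen-3-yl in place of 3-chloro-4-fluorophenyl on an amide-type nitrogen). Going by the values given here, no measured step covers an exchange of this kind; the only step in hand swaps one halogenated phenyl for another and is modest. Compound 3 is therefore expected to stay near the values seen, with an estimated step of a number 3.9 percentage points lower from compound 2 to compound 3 (within the scatter) that should remain within the scatter. The estimate for compound 3 in this assay is 40%, from 15% to 60%.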

Compound 3, percent growth inhibition at one concentration: 11%
Compound 3: the middle estimate sits 29 percentage points above what was measured, outside the stated range (below it).
By their numbers in this assay, from the lowest: compound 3; then compound 1; then compound 2.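

In this assay the group on the amide-type nitrogen matters far more than the exchange of one halogenated phenyl for another suggested: 2-acetoxythiophen-3-yl brings a number 32.9 percentage points lower from compound 2 to compound 3 (beyond the scatter) and also a number 21.5 percentage points lower from compound 1 to compound 3 (beyond the scatter), so this replacement falls beneath both halogenated phenyl compounds. No measurement shown here explains this fall.

Whether the thiophene ring or the acetoxy group accounts for it stays open, as the two enter together. A plain thiophen-3-yl, or one carrying methoxy in place of acetoxy, would separate them.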